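A few compounds are considered here, and "the series" means these few. Any claim that something is new, unique, unknown or untested is made for them only; others in the source may bear on it.

Compound 2 `CCNC(=O)c1cc(Oc2ccc(NC(=O)c3cc4cccnc4n(-c4ccccc4)c3=O)cc2)ccn1`: 160 nM
Compound 1 `CNC(=O)c1cc(Oc2ccc(NC(=O)c3cc4cccnc4n(-c4ccc(Br)cc4F)c3=O)cc2)ccn1`: 1420 nM

These two compounds were tested in a functional assay on A549 cells (Homo sapiens) for antiproliferative activity, read by MTT assay, with a stated time of 72 h; a higher number here means a weaker inhibitor, a lower number a stronger inhibitor. Compound 2 gives 160 nM, the lowest of the two numbers. Compound 1 gives 1420 nM, a higher number, and the gap between the two lies beyond the usual scatter of this assay; the two compounds differ in more than one place, so the two values alone do not show which change matters.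

Compound 3 `CCNC(=O)c1cc(Oc2ccc(NC(=O)c3cc4cccnc4n(-c4ccc(F)c(Cl)c4)c3=O)cc2)ccn1` has not yet been measured. It differs from compound 2 in one place: 3-chloro-4-fluorophenyl in place of phenyl on an aromatic nitrogen. For the measured compounds named here, no measured pair shows this change on its own, so the size of the step is not known from the data. Compound 3 is expected to stay close to compound 2, with a small step toward a higher number, about within the scatter, a 1.6-fold higher number from compound 2 to compound 3 (0.19 log units; within the scatter). The estimate for compound 3 is 250 nM, with a range from 80 nM to 800 nM.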

Compound 3, half-maximal inhibitory concentration: 1920 nM
For compound 3 the middle estimate is 7.7-fold (0.89 log units) below the measured one; the measured number lies above the stated range.
By their numbers in this assay, from the lowest: compound 2; then compounds 1 and 3 (each within the scatter of the next).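

On the aromatic nitrogen of the shared core, replacing phenyl with 3-chloro-4-fluorophenyl is far from a neutral swap: in this assay it gives a 12-fold higher number from compound 2 to compound 3 (1.08 log units; beyond the scatter), so the compound becomes a clearly weaker inhibitor of cell growth. Compounds 2 and 3 differ only in this group, so unlike the earlier pair, whose two compounds differ in more than one place, this pair ties the loss to a single change. The data shown offer no explanation for why the step is so large.

Chlorine and fluorine enter together, so their separate contributions remain unknown. Going by these compounds, it also remains open how this position would respond to a phenyl ring carrying only one of these halogens, or to one carrying an amine or a carboxylic acid.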